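Does a Branched Fluorophenyl Arm Change Cell Tolerance?

This account rests on a few compounds, and the source may have more. Where it says the series, first, only, none or still open, it means among the compounds named here.

Measured compounds and their values:
- Compound 1 `Cc1ccc2[nH]c(=O)c(CN(Cc3ccccc3)Cc3ccc(C(C)(C)C)cc3)cc2c1`: in a toxicity assay on MDCK cells (Canis lupus familiaris) for cytotoxicity, read by crystal violet staining, with a stated time of 48 h (a lower number here means that less compound is tolerated, a higher number that more compound is tolerated), compound 1 gives > 5000 nM, a limit of the assay.
- Compound 2 `Cc1ccc2[nH]c(=O)c(CN(CCCO)Cc3ccc(C(C)(C)C)cc3)cc2c1`: in this assay compound 2 gives > 10000 nM, a limit of the assay.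
- Compound 3 `Cc1ccc2[nH]c(=O)c(CN(Cc3ccc(OC(F)F)cc3)Cc3ccc(C(C)(C)C)cc3)cc2c1`: in this assay compound 3 gives > 5000 nM, a limit of the assay.

Compound 3 stands where two of the three values sit, at the limit of > 5000 nM in this assay, at which 2 of the 3 values shown sit. The third value sits at the limit of > 10000 nM in this assay, at which 1 of the 3 values shown sits. Every value is a limit. The measured steps therefore say nothing about size: a step that the two limits leave unreadable from compound 1 to compound 3 and a step that the two limits leave unreadable from compound 2 to compound 3 are both unreadable, as is a step that the two limits leave unreadable from compound 1 to compound 2. The cells tolerated all three compounds up to the highest amounts tested.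

Compound 4 `Cc1ccc2[nH]c(=O)c(CN(Cc3ccc(C(C)(C)C)cc3)[C@H](C)c3ccc(F)cc3)cc2c1` differs from compound 3 in one place: 1-(4-fluorophenyl)ethyl in place of 4-(difluoromethoxy)benzyl on an amine nitrogen. For the measured compounds named here, no measured step bears on this change in a readable way, so no direction can be read from the three compounds. The only signal is that three close relatives all stayed at a limit in this assay, so the expectation is that compound 4 also stays there, or at most moves within the scatter.

For compound 4 the estimated value is 8000 nM, with a range from 3000 nM to 30000 nM. This corresponds to an expected step that the limit leaves unreadable from compound 3 to compound 4, with a good chance that the assay again reports only a limit.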

Compound 4, half-maximal cytotoxic concentration: > 5000 nM
Compound 4 ended at the assay's limit; the forecaster's own chance of this, stated with the estimate: 75%; the middle value does not contradict the limit.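

In this assay compound 4 gives > 5000 nM, which is a limit. All four values are limits, and the steps from compound 1, compound 2 and compound 3 to compound 4 cannot be read. The compounds shown leave open at what concentration each one harms the cells, and whether 1-(4-fluorophenyl)ethyl in place of 4-(difluoromethoxy)benzyl shifts that concentration.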